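The compounds below may be only part of what the source reports. "The series", "measured", "known", "first", "only" and "open" are said of these compounds alone.

The series shares one core, and two of its members have been tested in a functional assay on A498 cells (Homo sapiens) for inhibition, read by MTT assay, with a stated time of 72 h; a higher number here means that more compound is tolerated, a lower number that less compound is tolerated. In this assay compound 1 `CC(C)(Oc1ccc(CCOc2ccc(NC(=O)c3ccccc3)cc2)cc1)C(=O)NS(=O)(=O)c1ccccc1` gives a measured value of 4600 nM. In the same test, compound 2 `CC(C)(Oc1ccc(CCOc2ccc(/N=N/c3ccccc3)cc2)cc1)C(=O)NS(=O)(=O)c1ccc(Cl)cc1` gives > 24000 nM, and this is a limit of the assay, not a number. Compound 2 therefore has no exact position on the scale, and any comparison with it must be read with that in mind.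

The next compound is compound 3 `CC(C)(Oc1ccc(CCOc2ccc(/N=N/c3ccccc3)cc2)cc1)C(=O)NS(=O)(=O)c1ccc([N+](=O)[O-])cc1`, which has nitro in place of chloro on an aromatic carbon, para to a large group, turning the 4-chlorophenyl into a 4-nitrophenyl: nitro in place of chloro on an aromatic carbon. Within the data shown here, no measured step in this small set shows what such an exchange does. The expectation therefore rests on compound 2, with its > 24000 nM, as the closest measured structure. The expected change, an at least 1.0-fold lower number from compound 2 to compound 3 (0.03 log units; that floor lies within the scatter), is none beyond the usual scatter, and no direction is favoured. Compound 3 may well return only a limit too. As a number, compound 3 is estimated at 22000 nM, with an expected range of 8000 nM to 48000 nM.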

Compound 3, half-maximal cytotoxic concentration: > 24000 nM
Compound 3: a limit, no number; the forecaster's own chance of this, stated with the estimate: 55%; middle value at least 1.0-fold (0.03 log units) from the limit.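

Compound 3, like compound 2, returns only a limit and not a number, so no step between compound 2 and compound 3 can be read: the limit of > 24000 nM in this assay, at which 2 of the 3 values shown sit.

The compounds shown leave open whether nitro in place of chloro on this 4-substituted phenyl changes the tolerated concentration in this assay at all.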